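Sulfamoyl carbamates of a hindered phenol: sulfonyl substituent variation

The source may hold more compounds than are shown below. What is called first, only, known or untested is meant among the compounds shown, and "the series" means these compounds.

Measured so far:
compound 1 `CC(C)c1cccc(C(C)C)c1OC(=O)NS(=O)(=O)N1CCc2ccccc21`, 43000 nM
compound 2 `CC(C)c1cccc(C(C)C)c1OC(=O)NS(=O)(=O)N(C(C)C)C(C)C`, 15000 nM
compound 3 `CC(C)c1cccc(C(C)C)c1OC(=O)NS(=O)(=O)N(C(C)C)C1CCCCC1`, 5100 nM

All three share one core and differ only in what sits on the sulfonyl sulfur. In an assay on liver for inhibition of sterol O-acyltransferase 1 (Rattus norvegicus), using microsomes (on this read-out lower numbers stand for stronger inhibition and higher numbers for weaker inhibition), compound 2 gives 15000 nM, the second highest of the three numbers; its nearest neighbour is compound 1 at 43000 nM, its furthest compound 3 at 5100 nM. The two steps run in the same direction: a 2.9-fold lower number from compound 1 to compound 2 (0.46 log units; beyond the scatter) and a 2.9-fold lower number from compound 2 to compound 3 (0.47 log units; beyond the scatter), both modest.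

Compound 4 `CC(C)c1cccc(C(C)C)c1OC(=O)NS(=O)(=O)Oc1c(F)cccc1F` is not yet measured. It differs from compound 2 by 2,6-difluorophenoxy in place of diisopropylamino on a sulfonyl sulfur. Neither measured step covers this kind of exchange; both concern amino groups on the sulfonyl sulfur and only show that changes there move this assay by modest amounts. No direction can therefore be read off for compound 4, and a step of about the size seen so far, in either direction or none beyond the scatter, is the expectation. Compound 4 is estimated at 20000 nM, range 5000 nM to 80000 nM, which would be a step of a 1.3-fold higher number from compound 2 to compound 4 (0.12 log units; within the scatter).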

Compound 4, half-maximal inhibitory concentration: 38000 nM
For compound 4 the middle estimate is 1.9-fold (0.28 log units) below the measured one; the range from low to high includes it.
By their numbers in this assay, from the lowest: compound 3; then compound 2; then compounds 4 and 1 (each within the scatter of the next).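

In this assay, 2,6-difluorophenoxy in place of diisopropylamino gives a 2.5-fold higher number from compound 2 to compound 4 (0.40 log units; beyond the scatter), so a change on the sulfonyl sulfur that is not an exchange between amino groups can raise the number, opposite in direction to the two earlier steps. Set against the amino group of compound 1, the same phenoxy group gives a 1.1-fold lower number from compound 1 to compound 4 (0.05 log units; within the scatter), which places compounds 1 and 4 together with no order between them, and among the four compounds the two groups carrying an aromatic ring give the two highest numbers, with none of the four going against this. Nothing available explains why the number moves with this exchange.

As far as these compounds go, whether unsubstituted phenoxy or isopropoxy would stay near compound 4 or come closer to compound 2 remains open. Also open, from the compounds shown here alone, is whether dicyclohexylamino on the sulfonyl sulfur would lower the number beyond that of compound 3.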